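This account rests on a few compounds, and the source may have more. Where it says the series, first, only, none or still open, it means among the compounds named here.

Compound 1 `CCc1cc(C)c(C(=O)N=C(N)N)cc1S(C)(=O)=O`: 4.8 nM
Compound 2 `Cc1c(C(=O)N=C(N)N)cc(S(C)(=O)=O)c(C)c1C`: 55 nM

Within the data shown here, in a functional assay for inhibition of sodium/hydrogen exchanger (Oryctolagus cuniculus) (a higher number here means a weaker inhibitor, a lower number a stronger inhibitor), compound 1 gives 4.8 nM, the lowest of the two numbers measured so far; compound 2 gives 55 nM, and that gap lies beyond the scatter. Compound 3 `Cc1cc(Sc2ccccc2)c(S(C)(=O)=O)cc1C(=O)N=C(N)N` has not yet been measured. It differs from compound 1 in one place: phenylsulfanyl in place of ethyl on an aromatic carbon. Among the measured compounds shown here, no step between two measured compounds covers this kind of change, so its size is open. A moderate step toward a higher number, beyond the scatter, is expected: a 3.1-fold higher number from compound 1 to compound 3 (0.49 log units; beyond the scatter). Compound 3 is therefore estimated at 15 nM, with a range from 4 nM to 60 nM.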

Compound 3, half-maximal inhibitory concentration: 14 nM
Beside the measured number, compound 3's estimate is 1.1-fold (0.03 log units) above it; the range from low to high includes it.
By their numbers in this assay, from the lowest: compound 1; then compound 3; then compound 2.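

In this assay, putting phenylsulfanyl in place of ethyl on this aromatic carbon, ortho to the methylsulfonyl group, gives a 2.9-fold higher number from compound 1 to compound 3 (0.46 log units; beyond the scatter), a modest step. This position therefore accepts a much larger group of 7 heavy atoms with its own aromatic ring, and compound 3 still gives 14 nM. Nothing measured here explains the rise in the number.

Going by these compounds, whether an amine, a phenoxy group or a longer chain at this position would give a lower or higher number remains open. On these data alone, it is also open whether the sulfur or the ring accounts for the step.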